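Trifluoromethyl Added Where Halogens Changed Nothing

The compounds below may be only part of what the source reports. "The series", "measured", "known", "first", "only" and "open" are said of these compounds alone.

Compound 1 `CC(C(=O)N1CCN(c2ccccc2)CC1)N1C(=O)CCC1=O` was tested in a functional assay on the whole organism (strain Swiss) with Mus musculus as the target, in the maximal electroshock model, with a stated time of 1 h, at a dose of 100 mg/kg by the intraperitoneal route (on this read-out higher numbers stand for a stronger effect at the one dose given and lower numbers for a weaker effect), where compound 1 gives 0%. Two close relatives carry a halogen on the same aromatic ring: compound 2 `CC(C(=O)N1CCN(c2ccc(Cl)cc2)CC1)N1C(=O)CCC1=O` gives 0% and compound 3 `CC(C(=O)N1CCN(c2ccc(F)cc2)CC1)N1C(=O)CCC1=O` gives 0%. The step of no change at the digits printed from compound 1 to compound 2 (within the scatter) and the step of no change at the digits printed from compound 1 to compound 3 (within the scatter) both showed nothing, as did no change at the digits printed from compound 2 to compound 3 (within the scatter), so compound 1 stands level with compounds 2 and 3 on these numbers.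

Compound 4 `CC(C(=O)N1CCN(c2ccccc2C(F)(F)F)CC1)N1C(=O)CCC1=O` is compound 1 with one change, (trifluoromethyl in place of hydrogen on an aromatic carbon). The group enters on an aromatic carbon of a six-membered aromatic ring of carbon only, ortho to a large group. Among the measured compounds shown here, no measured step places a trifluoromethyl, and none puts a group at that place; the halogen steps from compound 1 are the only guide, and each stayed within the scatter. The expected step of no change at the digits printed from compound 1 to compound 4 (within the scatter) is therefore small, with no clear direction. Compound 4 is estimated at 0%, within a range from 0% to 30%.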

Compound 4, a percentage reported as activity, at one dose (the size of the read-out at that dose, not a potency): 25%
Beside the measured number, compound 4's estimate is 25 percentage points below it; the range from low to high includes it.
By their numbers in this assay, from the lowest: compounds 1, 2 and 3 (each within the scatter of the next); then compound 4.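

Going from hydrogen to trifluoromethyl on an aromatic carbon, ortho to a large group, gives a number 25 percentage points higher from compound 1 to compound 4 (beyond the scatter) in this assay and is the first step from compound 1 that lies beyond the scatter. The aromatic ring of compound 1 can therefore take a substituent that brings a measurable effect at the one dose given, which the chloro and fluoro steps did not show. No measurement shown here bears on the reason for this step.

Among the compounds shown, only compound 4 carries a trifluoromethyl, and only compound 4 has a group at this place, so the effect of the group cannot be separated from that of its place. A methyl, a methoxy or a nitrile on the same carbon would help to separate the two.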